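Replacing the methoxypyridine on the shared core

A few compounds are considered here, and "the series" means these few. Any claim that something is new, unique, unknown or untested is made for them only; others in the source may bear on it.

In an ADME assay (liver) for metabolic stability, with Liver microsome (Homo sapiens) as the target, using microsomes and NADPH, with a stated time of 30 min, tested at 1 uM (a higher number here means faster removal of the compound, a lower number slower removal), compound 1 `COc1ccc(-c2cc(C(O)(C(F)(F)F)C(F)(F)F)cnc2N2CCN(S(=O)(=O)c3ccc(N)nc3)CC2)cn1` gives 25 mL.min-1.g-1 and compound 2 `COc1cncc(-c2cc(C(O)(C(F)(F)F)C(F)(F)F)cnc2N2CCN(S(=O)(=O)c3ccc(N)nc3)CC2)c1` gives 44 mL.min-1.g-1, so the two values lie within the scatter of each other. Compound 3 `Cc1nc2cc(-c3cc(C(O)(C(F)(F)F)C(F)(F)F)cnc3N3CCN(S(=O)(=O)c4ccc(N)nc4)CC3)ccc2o1` has not yet been measured. Its difference from compound 2 is 2-methyl-1,3-benzoxazol-5-yl in place of 5-methoxypyridin-3-yl on an aromatic carbon: 2-methyl-1,3-benzoxazol-5-yl in place of 5-methoxypyridin-3-yl, on an aromatic carbon ortho to a large group.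

Among the compounds with values here, only one measured step bears on this place: a 1.8-fold higher number from compound 1 to compound 2 (0.25 log units; within the scatter), which is within the scatter. That step exchanges one methoxypyridinyl group for another, whereas compound 3 carries a five-membered aromatic ring and a six-membered aromatic ring of carbon only. Within the data shown here, the data hold no step that removes the pyridine ring, so this guide is weak and the range must stay wide. No clear direction is expected in this assay, and no change beyond the scatter is expected. The estimated move is a 1.1-fold higher number from compound 2 to compound 3 (0.06 log units; within the scatter). For compound 3 the estimated value is 50 mL.min-1.g-1, with an expected range of 24 mL.min-1.g-1 to 100 mL.min-1.g-1.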

Compound 3, intrinsic clearance in microsomes: < 14 mL.min-1.g-1
Compound 3 ended at the assay's limit (the forecaster's own chance of this, stated with the estimate: 5%); at least 3.5-fold (0.55 log units) between middle value and limit.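

Compound 3 stands at a limit of the assay in this assay, not at a number: the limit of < 14 mL.min-1.g-1 in this assay, at which 1 of the 3 values shown sits. This position, on an aromatic carbon ortho to a large group, does respond to the group it carries, which the two methoxypyridinyl compounds could not show: the exchange for 2-methyl-1,3-benzoxazol-5-yl gives an at least 3.1-fold lower number from compound 2 to compound 3 (0.49 log units; beyond the scatter), whereas the earlier exchange gave only a 1.8-fold higher number from compound 1 to compound 2 (0.25 log units; within the scatter). The other comparison gives an at least 1.7-fold lower number from compound 1 to compound 3 (0.25 log units; that floor lies within the scatter), so slower removal beyond the scatter is established only against 5-methoxypyridin-3-yl, and 6-methoxypyridin-3-yl cannot yet be separated from the new group.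

As far as these compounds go, the full size of both steps stays unknown, since the value for compound 3 marks only where the read-out ends. Also open is which part of 2-methyl-1,3-benzoxazol-5-yl goes with the lower clearance: the compounds shown cannot separate the methyl group, the five-membered ring and the carbon-only six-membered ring, and a plain phenyl group or a benzoxazole lacking the methyl at this position would be needed to tell these apart.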